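A few compounds are considered here, and "the series" means these few. Any claim that something is new, unique, unknown or untested is made for them only; others in the source may bear on it.

Compound 2 `COc1cc2c(Oc3ccc(NS(=O)(=O)c4cc(F)ccc4F)cc3F)ccnc2cc1OCCCN1CCN(C)CC1` sits at the lower of the two numbers in an assay on isolated protein for inhibition of tyrosine-protein kinase receptor UFO (Homo sapiens); a higher number here means a weaker inhibitor, a lower number a stronger inhibitor: compound 2 gives 27 nM, while compound 1 `COc1cc2c(Oc3ccc(NS(=O)(=O)c4ccccc4OC(F)(F)F)cc3F)ccnc2cc1OCCCN1CCN(C)CC1` gives 51 nM, and the step of a 1.9-fold lower number from compound 1 to compound 2 (0.28 log units; within the scatter) stays within the scatter. Compound 3 `COc1cc2c(Oc3ccc(NS(=O)(=O)c4cc(F)ccc4F)cc3F)ccnc2cc1OCCCN1CCCC(C)C1` differs from compound 2 by 3-methylpiperidin-1-yl in place of 4-methylpiperazin-1-yl on a saturated chain carbon, three bonds along the chain from an oxygen on an aromatic ring. Among the measured compounds shown here, the only step on record, a 1.9-fold lower number from compound 1 to compound 2 (0.28 log units; within the scatter), concerns the aryl group on the sulfonyl sulfur, not the chain terminus, so no measured step bears on this change. For the measured compounds named here, with no precedent, the estimated step of a 1.1-fold higher number from compound 2 to compound 3 (0.05 log units; within the scatter) is expected to stay within the scatter. Compound 3 is therefore estimated at 30 nM, with a range from 10 nM to 90 nM.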

Compound 3, half-maximal inhibitory concentration in the tyrosine-protein kinase receptor UFO assay: 28 nM
Estimate against measurement, compound 3: 1.1-fold (0.03 log units) above; low and high end bracket the measured number.
By their numbers in the tyrosine-protein kinase receptor UFO assay, from the lowest: compounds 2, 3 and 1 (each within the scatter of the next).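

The chain terminus now has a reading: in the tyrosine-protein kinase receptor UFO assay, 3-methylpiperidin-1-yl replaces 4-methylpiperazin-1-yl with no change beyond the scatter (a 1.0-fold higher number from compound 2 to compound 3 (0.02 log units; within the scatter)), so this position accepts a six-membered ring with one hetero atom as well as one with two. The same change does separate the two compounds in a physicochemical assay for solubility, read by HPLC, with a stated time of 24 h, at pH 7.4 (on this read-out lower numbers stand for lower solubility and higher numbers for higher solubility), where compound 2 gives 68800 nM and compound 3 gives 18000 nM: the measured solubility of compound 2, 68800 nM, and of compound 3, 18000 nM, a 3.8-fold lower number (0.58 log units; beyond the scatter).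

Still open, on these data alone, is whether morpholin-4-yl or unsubstituted piperidin-1-yl at this position would match compound 2 in both assays. As far as these compounds go, it is also open whether the methyl group on the piperidine ring contributes to the difference seen with compound 3.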